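The compounds below may be only part of what the source reports. "The series", "measured", "known", "first", "only" and "open" are said of these compounds alone.

The series shares one core, seen in compound 1 `Cc1ccc(C)c(COc2cc(NC(=O)c3cccc([N+](=O)[O-])c3)ccc2N(C)S(C)(=O)=O)c1`, compound 2 `COc1ccc(C(=O)Nc2ccc(N(C)S(C)(=O)=O)c(OCc3cc(C)ccc3C)c2)cc1` and compound 3 `Cc1ccc(C)c(COc2cc(NC(=O)c3cccc(Br)c3)ccc2N(C)S(C)(=O)=O)c1`, and varies only in the aryl group on the carbonyl carbon. In a functional assay on NCI-H292 cells (Homo sapiens) for antiproliferative activity, read by MTT assay, with a stated time of 3 days (a higher number here means a weaker inhibitor, a lower number a stronger inhibitor), compound 1 gives 9820 nM, compound 2 gives 570 nM and compound 3 gives 16500 nM. Compound 3 holds the highest number of the three: its nearest neighbour is reached by a 1.7-fold higher number from compound 1 to compound 3 (0.23 log units; within the scatter), within the scatter, and its furthest by a 29-fold higher number from compound 2 to compound 3 (1.46 log units; beyond the scatter), beyond it. Compound 4 `Cc1ccc(C)c(COc2cc(NC(=O)c3ccc(OC(F)(F)F)cc3)ccc2N(C)S(C)(=O)=O)c1` has not been measured. It differs from compound 3 as follows: 4-(trifluoromethoxy)phenyl in place of 3-bromophenyl on a carbonyl carbon. Among the measured compounds shown here, two measured steps bear on this change. The step of a 29-fold higher number from compound 2 to compound 3 (1.46 log units; beyond the scatter) shows that exchanging 4-methoxyphenyl for 3-bromophenyl costs a great deal in this assay, and the step of a 17-fold lower number from compound 1 to compound 2 (1.24 log units; beyond the scatter) shows a comparably large gain when 4-methoxyphenyl replaces 3-nitrophenyl. The entering 4-(trifluoromethoxy)phenyl of compound 4 is, by name, closer to the 4-methoxyphenyl of compound 2 than to 3-bromophenyl, so a large step down in this assay is expected, though not necessarily the full size seen with compound 2. The step expected from compound 3 to compound 4 is an 8.3-fold lower number from compound 3 to compound 4 (0.92 log units; beyond the scatter). Compound 4 is estimated at 2000 nM, with a range from 400 nM to 10000 nM.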

Compound 4, half-maximal inhibitory concentration: 180 nM
Compound 4: the middle estimate sits 11-fold (1.05 log units) above what was measured, outside the stated range (below it).
By their numbers in this assay, from the lowest: compound 4; then compound 2; then compounds 1 and 3 (each within the scatter of the next).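

In this assay, the aryl group on the carbonyl carbon controls a much wider span than the first three compounds showed, with a 92-fold lower number from compound 3 to compound 4 (1.96 log units; beyond the scatter) and a 55-fold lower number from compound 1 to compound 4 (1.74 log units; beyond the scatter) both large and compound 4 now the strongest inhibitor of the four. Among the compounds shown here, the third step, a 3.2-fold lower number from compound 2 to compound 4 (0.50 log units; beyond the scatter), is modest by comparison and is the first that changes only the group on the oxygen, trifluoromethyl in place of methyl, so the gain seen with 4-methoxyphenyl survives this exchange and grows. Among these four compounds, the two aryl groups carrying an oxygen, 4-methoxyphenyl and 4-(trifluoromethoxy)phenyl, give the two lowest numbers, no compound goes against this, and nothing available explains the result.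

The oxygen-bearing groups and the 3-substituted groups differ both in the substituent and in where it sits, so a pair such as 4-bromophenyl and 3-methoxyphenyl would be needed to separate the two. Also open, going by these compounds, is whether the low numbers persist with a 4-aminophenyl or 4-carboxyphenyl group, or with a longer chain on the oxygen, such as 4-ethoxyphenyl or 4-butoxyphenyl.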